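Methyl on the amide-type nitrogen of compound 1

The source may report more compounds than this note shows. Statements on the series, on what has been measured and on what is new or still open speak of the compounds shown alone.

Going by the values given here, in a functional assay on Rec1 cells (Homo sapiens) for inhibition, read by MTT assay, with a stated time of 48 h (a higher number here means a weaker inhibitor of growth, a lower number a stronger inhibitor of growth), compound 1 (`Nc1nc(Nc2ccccc2)nc2c1CC(c1c(Cl)cccc1Cl)C(=O)N2`) gives 52300 nM as the only actual number. Compound 2 (`Nc1nc(N)c2c(n1)NC(=O)C(c1c(Cl)cccc1Cl)C2`) gives > 100000 nM and this is a limit, not a number. Compound 3 (`Nc1nc(Nc2ccccc2)nc2[nH]c(=O)c(-c3c(Cl)cccc3Cl)cc12`) gives > 100000 nM and this too is a limit. Any clear weakening from compound 1 would therefore soon meet the limit of > 100000 nM in this assay, at which 2 of the 3 values shown sit, and yield no number.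

The next compound to be tested is compound 4 (`CN1C(=O)C(c2c(Cl)cccc2Cl)Cc2c(N)nc(Nc3ccccc3)nc21`). It has methyl in place of hydrogen on an amide-type nitrogen in a ring. This nitrogen lies two ring bonds from the ring atom that bears a 2,6-dichlorophenyl group.

Among the compounds with values here, the one measured step, an at least 1.9-fold higher number from compound 1 to compound 2 (0.28 log units; that floor lies within the scatter) with hydrogen in place of phenyl on a nitrogen on an aromatic ring, concerns a different place. Its floor also stays within the scatter, so it gives no size for the present change. Within the data shown here, no measured step touches the amide-type nitrogen, and no shift beyond the scatter is expected in this assay in either direction. The expected result is a 1.1-fold higher number from compound 1 to compound 4 (0.02 log units; within the scatter) and no more. Compound 4 has the estimated value 55000 nM within an expected range from 20000 nM to 100000 nM in this assay, and a result reported only as a limit remains possible.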

Compound 4, concentration for 50% growth inhibition: 1300 nM
Compound 4: middle estimate off by 42-fold (1.63 log units), on the high side; the measured number lies below the stated range.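

In this assay, going by these compounds alone, the amide-type nitrogen in a ring proves to be a sensitive place: methyl in place of hydrogen there gives the first step that can be read as beyond the scatter (a 40-fold lower number from compound 1 to compound 4 (1.60 log units; beyond the scatter)). Within the data shown here, a change of a single heavy atom, with no hydrogen-bond acceptor added, is therefore enough to move the number by a large amount, whereas the only earlier step, at the nitrogen on an aromatic ring, gave no size at all. Among these compounds, compound 4 also gives the series a second actual number, one that stands well clear of the ceiling that hid the earlier comparisons: (the limit of > 100000 nM in this assay, at which 2 of the 4 values shown sit).

The compounds shown leave open whether ethyl, a longer chain or a chain ending in an amine on this same nitrogen would extend the step or lose it, and they offer no measurement that explains it. They also leave open whether methyl at this nitrogen would bring a similar step on the core of compound 2 or of compound 3, neither of which has yet given an actual number.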